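Chloro for Methoxy on a Scaffold Near the Assay Limit

The source may report more compounds than this note shows. Statements on the series, on what has been measured and on what is new or still open speak of the compounds shown alone.

Compound 1 `COc1ccc(N2C(=O)COc3ccc(-c4cnc5ccccc5c4)cc32)cc1` is one of three compounds examined in a functional assay on MCF7 cells (Homo sapiens) for antiproliferative activity, read by MTT assay, with a stated time of 72 h; a higher number here means a weaker inhibitor, a lower number a stronger inhibitor. In this assay compound 1 gives > 40000 nM, which is a limit of the assay rather than a number. Compound 3 `O=C1COc2ccc(-c3cnc(Cl)c(NS(=O)(=O)c4ccc(F)cc4)c3)cc2N1c1ccccc1` likewise sits at a limit, giving > 40000 nM in this assay. Compound 2 `COc1ccc(N2C(=O)COc3ccc(-c4cnc(OC)c(NS(=O)(=O)c5ccc(F)cc5)c4)cc32)cc1` is the only one of the three with a measured number, 8260 nM in this assay. The picture is dominated by the limit of > 40000 nM in this assay, at which 2 of the 3 values shown sit. Compound 4 `O=C1COc2ccc(-c3cnc4ccccc4c3)cc2N1c1ccc(Cl)cc1` has not yet been measured; it differs from compound 1 by chloro in place of methoxy on an aromatic carbon. Within the data shown here, no measured pair in this set shares that change, so the size of its effect cannot be read from the data. Compound 1 stands at > 40000 nM in this assay, a limit. The step of a number no higher from compound 1 to compound 4 (the limit leaves the size open) is expected to be small, with no clear direction beyond the scatter. Compound 4 is therefore estimated to give about 40000 nM in this assay, between 15000 nM and 100000 nM, and most likely to be reported again only as a limit.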

Compound 4, half-maximal inhibitory concentration: > 40000 nM
Compound 4 ended at the assay's limit; the forecaster's own chance of this, stated with the estimate: 70%; the middle value lies on the limit itself.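

No step can be read from compound 1 to compound 4, because both stand only as limits in this assay and the set is dominated by that limit: the limit of > 40000 nM in this assay, at which 3 of the 4 values shown sit. The compounds shown leave open how far chloro in place of methoxy on an aromatic carbon shifts antiproliferative activity.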